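Triazole hydroxamates: aryl group swap at the triazole carbon

The compounds below may be only part of what the source reports. "The series", "measured", "known", "first", "only" and "open" are said of these compounds alone.

Measured compounds:
compound 1 `O=C(NO)c1ccc(NCc2nc(-c3ccc(Br)o3)nn2-c2ccccc2)cc1`, 55.8%
compound 2 `CCc1ccc(-c2nc(CNc3ccc(C(=O)NO)cc3)n(-c3ccccc3)n2)cc1`, 54.6%
compound 3 `O=C(NO)c1ccc(NCc2nc(-c3ccc(Cl)c(Cl)c3)nn2-c2ccccc2)cc1`, 34.5%

All three share one core and differ only in the aryl group on the five-membered aromatic ring with three nitrogen atoms. In an assay on Sf9 cells for inhibition of protein deacetylase HDAC6 (Homo sapiens), read by fluorescence, with a stated time of 40 min, tested at 100 nM (a higher number here means more inhibition at the concentration tested (going by the name of the read-out), a lower number less inhibition), compound 3 gives the lowest of the three numbers; a number 21.3 percentage points lower from compound 1 to compound 3 (beyond the scatter) and a number 20.1 percentage points lower from compound 2 to compound 3 (beyond the scatter), while a number 1.2 percentage points lower from compound 1 to compound 2 (within the scatter).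

Compound 4 `CC(C)c1ccc(-c2nc(CNc3ccc(C(=O)NO)cc3)n(-c3ccccc3)n2)cc1` has not been measured. It differs from compound 3 by 4-isopropylphenyl in place of 3,4-dichlorophenyl on an aromatic carbon. The two steps that bear on this are the ones into compound 3, both downward and beyond the scatter from the 5-bromofuran-2-yl and 4-ethylphenyl compounds. Compound 4 carries a 4-isopropylphenyl group where compound 2 carries 4-ethylphenyl; on this basis the reverse step is expected, so that a number 18.5 percentage points higher from compound 3 to compound 4 (beyond the scatter) is estimated to lie beyond the scatter, upward. Compound 4 is accordingly expected to give about 53%, with a range from 40% to 66%.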

Compound 4, a percentage reported as inhibition, at one concentration (the size of the read-out at that concentration, not a potency): 27.6%
Compound 4: the middle estimate sits 25.4 percentage points above what was measured; measured number below the stated range.
By their numbers in this assay, from the lowest: compounds 4 and 3 (each within the scatter of the next); then compounds 2 and 1 (each within the scatter of the next).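

In this assay, the alkyl group on this aryl ring proves not to be a neutral place for change: with methyl in place of hydrogen on the saturated chain carbon, a number 27 percentage points lower from compound 2 to compound 4 (beyond the scatter). The level shared by the 5-bromofuran-2-yl and 4-ethylphenyl compounds is not kept by 4-isopropylphenyl, as a number 28.2 percentage points lower from compound 1 to compound 4 (beyond the scatter), while a number 6.9 percentage points lower from compound 3 to compound 4 (within the scatter), which leaves 4-isopropylphenyl and 3,4-dichlorophenyl unseparated at this position. Nothing available explains the drop on going from 4-ethylphenyl to 4-isopropylphenyl.

Open, on these data alone, is how the number behaves with a 4-methylphenyl, a 4-tert-butylphenyl or a 4-aminophenyl group on this carbon. Each figure is also a read-out at one concentration, so the relative potencies of these compounds remain open.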